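The compounds below may be only part of what the source reports. "The series", "measured", "known", "first", "only" and "open" are said of these compounds alone.

Measured in a functional assay on MOLT-4 cells (Homo sapiens) for inhibition, read by sulforhodamine B assay, with a stated time of 48 h; on this read-out higher numbers stand for weaker inhibition of growth and lower numbers for stronger inhibition of growth:
compound 1 `O=C(Cc1csc2nc(-c3ccc(Br)cc3)cn12)N/N=C/c1ccccc1O` gives 2340 nM
compound 2 `COc1cccc(OC)c1/C=N/NC(=O)Cc1csc2nc(-c3ccc(Br)cc3)cn12` gives 3470 nM

Among the measured compounds shown here, only two values exist so far, and they lie within the scatter of each other, so compound 2 stands level with compound 1 : a 1.5-fold higher number from compound 1 to compound 2 (0.17 log units; within the scatter).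

Compound 3 `O=C(Cc1csc2nc(-c3ccc(Br)cc3)cn12)N/N=C/c1ccc(Cl)cc1Cl` has not yet been measured. It carries 2,4-dichlorophenyl in place of 2,6-dimethoxyphenyl on a carbon with a double bond to nitrogen.

For the measured compounds named here, only one measured step touches this place, the exchange of 2-hydroxyphenyl for 2,6-dimethoxyphenyl on that same carbon. Going by the values given here, no measured compound carries 2,4-dichlorophenyl, so the data give no direct reading of the new group, and the range must stay wide. Among the compounds with values here, with compound 2 as the starting point and a 1.5-fold higher number from compound 1 to compound 2 (0.17 log units; within the scatter) as the only guide, no change beyond the scatter is expected in this assay, and no direction can be firmly assigned. The expected move is a 1.3-fold lower number from compound 2 to compound 3 (0.11 log units; within the scatter). The estimate for compound 3 is 2700 nM, with an expected range from 900 nM to 8000 nM.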

Compound 3, concentration for 50% growth inhibition: 1000 nM
Compound 3: middle estimate off by 2.7-fold (0.43 log units), on the high side; the measured number falls inside the stated range.
By their numbers in this assay, from the lowest: compound 3; then compounds 1 and 2 (each within the scatter of the next).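

In this assay, the group on the carbon with a double bond to nitrogen now shows an effect on the read-out beyond the scatter: 2,4-dichlorophenyl gives a 3.5-fold lower number from compound 2 to compound 3 (0.54 log units; beyond the scatter) when it takes the place of 2,6-dimethoxyphenyl, and a 2.3-fold lower number from compound 1 to compound 3 (0.37 log units; beyond the scatter) when it takes the place of 2-hydroxyphenyl. Among the compounds shown here, the earlier exchange of 2-hydroxyphenyl for 2,6-dimethoxyphenyl gave no separation, so compound 3 is the first sign that this position responds to the choice of aryl group, and its steps to both other compounds place it as the strongest inhibitor of growth of the three. No supporting measurement bears on why the 2,4-dichlorophenyl compound stands apart.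

The compounds shown leave open whether both chlorine atoms are needed, since a single chlorine on the phenyl ring, as in 4-chlorophenyl, could separate the contribution of each one. They also leave open whether the position accepts anything other than a substituted phenyl ring, such as a pyridine ring or a cyclohexyl group, and whether the step from compound 2 to compound 3 holds when the bromine on the shared core is exchanged for another group.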